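The source may hold more compounds than are shown below. What is called first, only, known or untested is meant among the compounds shown, and "the series" means these compounds.

Values in a functional assay on the whole organism with Scenedesmus acutus as the target, with a stated time of 20 h; on this read-out higher numbers stand for weaker inhibition and lower numbers for stronger inhibition:
Compound 1 `CC(C)OC(=O)c1cc(N2C(=O)C3=C(CCCC3)C2=O)ccc1Cl`: 182 nM
Compound 2 `CC(C)OC(=O)c1cc(N2C(=O)C3=C(CCCC3)C2=O)c(F)cc1Cl`: 89.1 nM
Compound 3 `C#CCOc1cc(N2C(=O)C3=C(CCCC3)C2=O)ccc1Cl`: not yet measured

Compound 1 has the higher number of the two measured compounds, so it is the weaker inhibitor in this assay. For the measured compounds named here, the only measured step is a 2.0-fold lower number from compound 1 to compound 2 (0.31 log units; beyond the scatter). This modest step puts fluoro in place of hydrogen on an aromatic carbon and leaves the isopropoxycarbonyl untouched.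

Compound 3 keeps the shared core of compound 1 but carries propargyloxy in place of isopropoxycarbonyl on an aromatic carbon. Going by the values given here, no measured step tests this exchange, so the fluoro step offers only a rough guide to size, and the direction remains uncertain. A modest shift towards a lower number is expected, with a wide margin.

The expected step is a 1.5-fold lower number from compound 1 to compound 3 (0.18 log units; within the scatter).

For compound 3 the estimated value is 120 nM, with an expected range of 30 nM to 480 nM.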

Compound 3, half-maximal inhibitory concentration: 537 nM
Estimate against measurement, compound 3: 4.5-fold (0.65 log units) below, outside the stated range (above it).
By their numbers in this assay, from the lowest: compound 2; then compound 1; then compound 3.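

In this assay, propargyloxy in place of isopropoxycarbonyl gives a 3.0-fold higher number from compound 1 to compound 3 (0.47 log units; beyond the scatter), so the group at this position, ortho to a chloro group, clearly bears on the read-out, and this exchange weakens inhibition. The earlier step, a 2.0-fold lower number from compound 1 to compound 2 (0.31 log units; beyond the scatter), left the isopropoxycarbonyl untouched, so it said nothing about this position and ran in the opposite direction to the new step. No measurement at hand gives a reason for the rise.

Going by these compounds, whether the rise comes from losing the isopropoxycarbonyl or from introducing propargyloxy stays open, and a methoxy, a longer alkoxy chain or a carboxylic acid at this position would help separate the two. On these data alone, it is also open whether the fluoro exchange would lower the number on compound 3 as it did on compound 1.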